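Aminothiophene piperazines: varying the distal nitrogen substituent

This account rests on a few compounds, and the source may have more. Where it says the series, first, only, none or still open, it means among the compounds named here.

Measured so far:
- Compound 1, `Nc1scc(CN2CCN(c3ccc(F)cc3Cl)CC2)c1C(=O)c1ccc(Cl)cc1`: 0%
- Compound 2, `Nc1scc(CN2CCN(C3CCCCCC3)CC2)c1C(=O)c1ccc(Cl)cc1`: 0%

Compound 2 stands level with compound 1 in an assay on CHO cells for displacement of a labelled ligand from adenosine receptor A1 (Homo sapiens), read by scintillation counting, with a stated time of 120 min, tested at 10 uM; a higher number here means more inhibition at the concentration tested (going by the name of the read-out), a lower number less inhibition; the step of no change at the digits printed from compound 1 to compound 2 (within the scatter) shows no shift beyond the scatter. Compound 3, `Nc1scc(CN2CCN(CCCc3ccc(Cl)cc3)CC2)c1C(=O)c1ccc(Cl)cc1`, differs from compound 2 in one place: 3-(4-chlorophenyl)propyl in place of cycloheptyl on an amine nitrogen in a ring. Within the data shown here, the only step bearing on this change is the exchange of an aryl for a saturated ring on the same nitrogen, and it gave nothing. The expected step is therefore none beyond the scatter, a number 4 percentage points higher from compound 2 to compound 3 (within the scatter), and compound 3 is estimated at 4% in this assay, within 0% to 22%.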

Compound 3, a percentage reported as inhibition, at one concentration (the size of the read-out at that concentration, not a potency): 0%
Compound 3: middle estimate off by 4 percentage points, on the high side, and the stated range covers the measured number.
By their numbers in this assay, from the lowest: compounds 1, 2 and 3 (each within the scatter of the next).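

Moving the aromatic ring out onto a chain, as 3-(4-chlorophenyl)propyl, gives this nitrogen a kind of substituent that neither 2-chloro-4-fluorophenyl nor cycloheptyl represents, yet this assay records no change at the digits printed from compound 2 to compound 3 (within the scatter) and no change at the digits printed from compound 1 to compound 3 (within the scatter). Aryl, saturated ring and arylalkyl groups on this amine nitrogen in a ring therefore cannot be told apart here, as all three compounds sit at the floor of the read-out.

From the compounds shown here alone, whether a longer chain, an amide or a carboxylic acid on this nitrogen would give any inhibition in this assay remains open. No evidence at hand bears on this flat result.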